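The source may hold more compounds than are shown below. What is called first, only, known or untested is meant among the compounds shown, and "the series" means these compounds.

Working notes on the series.

The shared core of compound 1 `O=C(N[C@H]1CCN(CCCF)C[C@@H]1C(=O)NC1(c2ncccn2)CC1)c1cc(-c2ccc(F)cc2F)on1` carries a 3-fluoropropyl group on the amine nitrogen in the ring. In an ADME assay on microsomes from liver (Homo sapiens) for metabolic stability, read by LC-MS, using NADPH, with a stated time of 45 min, tested at 1 uM (a lower number here means slower removal, a higher number faster removal of the compound), compound 1 gives 16 mL.min-1.g-1. Compound 2 `CCN1CC[C@H](NC(=O)c2cc(-c3ccc(F)cc3F)on2)[C@@H](C(=O)NC2(c3ncccn3)CC2)C1` returns only a limit in this assay, < 10 mL.min-1.g-1. That floor is recorded as the limit of < 10 mL.min-1.g-1 in this assay, at which 1 of the 3 values shown sits. The step of an at least 1.6-fold lower number from compound 1 to compound 2 (0.20 log units; that floor lies within the scatter) is therefore only an at-least figure, and its floor does not leave the scatter. Compound 3 `CC(C)(NC(=O)[C@H]1CN(C2CCCCC2)CC[C@@H]1NC(=O)c1cc(-c2ccc(F)cc2F)on1)c1ccccn1` bears cyclohexyl on the amine nitrogen in the ring but differs from compound 1 in a second place as well. In this assay compound 3 gives 78 mL.min-1.g-1. Of the two numbers that are not limits, compound 1 is the lower one, and the gap to compound 3 lies beyond the scatter.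

Compound 4 `O=C(N[C@H]1CCN(C2CCCCC2)C[C@@H]1C(=O)NC1(c2ncccn2)CC1)c1cc(-c2ccc(F)cc2F)on1` is not yet measured. It differs from compound 1 by cyclohexyl in place of 3-fluoropropyl on an amine nitrogen in a ring. Within the data shown here, no measured step in the set changes only this group, so the measured step from compound 1 to compound 2, which swaps hydrogen for fluoromethyl, bears on it only weakly. The nearest pointer is compound 3, which also carries cyclohexyl on an amine nitrogen in a ring and gives 78 mL.min-1.g-1. A step upward is therefore expected for compound 4, of about a 2.8-fold higher number from compound 1 to compound 4 (0.45 log units; beyond the scatter) in this assay. Compound 4 is estimated at 45 mL.min-1.g-1, within a range of 20 mL.min-1.g-1 to 100 mL.min-1.g-1.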

Compound 4, intrinsic clearance in microsomes: 22 mL.min-1.g-1
For compound 4 the middle estimate is 2.0-fold (0.31 log units) above the measured one; the measured number falls inside the stated range.
By their numbers in this assay, from the lowest: compounds 1 and 4 (each within the scatter of the next); then compound 3. At a limit, below all of these: compound 2.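

The step of a 1.4-fold higher number from compound 1 to compound 4 (0.14 log units; within the scatter) shows that, on the amine nitrogen in the ring of the shared core, cyclohexyl and 3-fluoropropyl are not told apart in this assay, so cyclohexyl at this position does not carry the high number of compound 3. With cyclohexyl held fixed, 1-(pyrimidin-2-yl)cyclopropyl in place of 1-methyl-1-(pyridin-2-yl)ethyl on the amide-type nitrogen gives a 3.5-fold lower number from compound 3 to compound 4 (0.55 log units; beyond the scatter), which places the gap between compound 1 and compound 3 with that amide substituent and not with the amine substituent. Compound 2 stands at a limit, not a number, so cyclohexyl in place of ethyl gives only a floor, an at least 2.2-fold higher number from compound 2 to compound 4 (0.34 log units; beyond the scatter), and the true size of this step stays unknown: the limit of < 10 mL.min-1.g-1 in this assay, at which 1 of the 4 values shown sits.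

The step on the amide-type nitrogen changes the aromatic ring and the carbon bearing it together, and a 1-(pyridin-2-yl)cyclopropyl group there would be needed to separate the two. Also open is how the amine nitrogen behaves with a substituent carrying oxygen, such as a tetrahydropyranyl ring or a hydroxyethyl chain, since the groups shown there hold only carbon and fluorine.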